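The source may report more compounds than this note shows. Statements on the series, on what has been measured and on what is new or still open speak of the compounds shown alone.

Of the compounds shown here, two have been tested in a functional assay on HCT-116 cells (Homo sapiens) for antiproliferative activity, read by MTT assay, with a stated time of 72 h (on this read-out higher numbers stand for weaker inhibition and lower numbers for stronger inhibition), so far, and neither gave a number. Compound 1, `O=C1COc2ccc(-c3cccc(NS(=O)(=O)c4ccc(F)cc4)c3)cc2N1c1ccccc1`, reaches only the limit of the measurement: in this assay compound 1 gives > 40000 nM. Compound 2, `COc1cccc(N2C(=O)COc3ccc(-c4cnc(Cl)c(NS(=O)(=O)c5ccc(F)cc5)c4)cc32)c1`, a close relative, also stops at the limit, and in this assay compound 2 gives > 40000 nM. For the measured compounds named here, both values sit at the limit of > 40000 nM in this assay, at which 2 of the 2 values shown sit, so compound 1 stands at the limit itself, with no measured step to any neighbour. Compound 3, `Cc1ccc(N2C(=O)COc3ccc(-c4cccc(NS(=O)(=O)c5ccc(F)cc5)c4)cc32)cc1`, differs from compound 1 by a single change: methyl in place of hydrogen on an aromatic carbon. Because compound 1 rests at the limit of > 40000 nM in this assay, at which 2 of the 2 values shown sit, the small change offers no basis for a large shift. A step of a number no higher from compound 1 to compound 3 (the limit leaves the size open) is expected, none beyond the usual scatter. For compound 3 the estimated value in this assay is 40000 nM, within a range from 15000 nM to 100000 nM, most likely reported again only as a limit.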

Compound 3, half-maximal inhibitory concentration: 35600 nM
Beside the measured number, compound 3's estimate is 1.1-fold (0.05 log units) above it; measured number inside the range.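

Compound 3 gives the series its first real number in this assay, a value that later changes can be compared with. Going from phenyl to 4-methylphenyl, with the methyl on an aromatic carbon para to a large group, gives an at least 1.1-fold lower number from compound 1 to compound 3 (0.05 log units; that floor lies within the scatter), so this one small addition is enough to bring the read-out within measurable range, though it stays weak. The true size of the step remains unknown, since the value for compound 1 is only a limit: the limit of > 40000 nM in this assay, at which 2 of the 3 values shown sit.

The compounds shown leave open whether a larger or different group at this position, such as an amine, a carboxylic acid or a longer chain like propyl, would give a much lower number. They also cannot tell whether any such change would matter more than this methyl.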